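The source may hold more compounds than are shown below. What is called first, only, known or untested is meant among the compounds shown, and "the series" means these compounds.

Measured so far in an ADME assay on microsomes from liver (Homo sapiens) for metabolic stability; on this read-out lower numbers stand for slow clearance and higher numbers for fast clearance:

Compound 1 `Cc1c(Cc2ccc(-c3cocn3)cc2)cc(C(=O)N[C@H]2CCCC[C@@H]2O)c(=O)n1C` — compound 1 gives 17 mL/min/kg.
Compound 2 `Cc1c(Cc2ccc(-c3ccn(C)n3)cc2)cc(C(=O)N[C@H]2CCCC[C@@H]2O)c(=O)n1C` — compound 2 gives 13 mL/min/kg.
Compound 3 `Cc1cc(F)c(C(=O)N[C@H]2CCOC[C@@H]2O)cc1Cc1ccc(-n2cccn2)cc1` — for compound 3 the assay reports only a limit, < 10 mL/min/kg.

Compound 3 thus sits at the limit of < 10 mL/min/kg in this assay, at which 1 of the 3 values shown sits, with no number behind it. Among the measured compounds shown here, the one measured step, a 1.3-fold lower number from compound 1 to compound 2 (0.12 log units; within the scatter), concerns a different position and stays within the scatter.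

Compound 4 `Cc1ccc(C(=O)N[C@H]2CCOC[C@@H]2O)cc1Cc1ccc(-n2cccn2)cc1` differs from compound 3 by hydrogen in place of fluoro on an aromatic carbon. For the measured compounds named here, no measured step touches this change, so nothing points to a shift in this assay beyond the scatter. Compound 4 is therefore expected near the limit of compound 3, estimated at 11 mL/min/kg, between 5 mL/min/kg and 22 mL/min/kg. The expected step is an at least 1.1-fold higher number from compound 3 to compound 4 (0.04 log units; that floor lies within the scatter).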

Compound 4, clearance: < 8 mL/min/kg
Compound 4 was reported as a limit; the forecaster's own chance of this, stated with the estimate: 40%; middle value at least 1.3-fold (0.13 log units) from the limit.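

Compound 3 and compound 4 are both reported only as limits in this assay, and no step can be read between them. Still open, as far as these compounds go, is how far hydrogen in place of fluoro on an aromatic carbon moves clearance, if at all.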